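Rat liver microsome stability across the shared core

A few compounds are considered here, and "the series" means these few. Any claim that something is new, unique, unknown or untested is made for them only; others in the source may bear on it.

Compound 1, `N#Cc1ccc(-c2nc(NCCNc3ccc([N+](=O)[O-])c(N)n3)ncc2-c2ncc[nH]2)cc1`: in an ADME assay on microsomes from liver (Rattus norvegicus) for metabolic stability (a lower number here means that the compound disappears faster, a higher number that the compound lasts longer), compound 1 gives > 0.5 h, which is a limit of the assay and not a number.
Compound 2, `N#Cc1ccc(NCCNc2ncc(-c3ncc[nH]3)c(-c3ccc(Cl)cc3Cl)n2)nc1`: in this assay compound 2 gives > 0.5 h, again a limit.
Compound 3, `Nc1nc(NCCNc2ncc(-c3ncc[nH]3)c(-c3ccc(C(F)(F)F)cc3)n2)ccc1[N+](=O)[O-]`: in this assay compound 3 gives > 0.5 h, again a limit.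

Compound 1 stands on a limit only, and the two other values shown are limits as well; nothing places compound 1 above or below either of them. Among the measured compounds shown here, the one measured step, a step that the two limits leave unreadable from compound 1 to compound 3, cannot be read because both ends of it sit at the same limit, as the limit of > 0.5 h in this assay, at which 3 of the 3 values shown sit, shows.

Compound 4, `Nc1nc(NCCNc2ncc(-c3ncc[nH]3)c(-c3ccccc3Cl)n2)ccc1[N+](=O)[O-]`, is not yet measured in this assay. Its change from compound 1 is 2-chlorophenyl in place of 4-cyanophenyl on an aromatic carbon. For the measured compounds named here, no measured step bears on this change in a readable way: the only step, from compound 1 to compound 3, changes a different group and is itself unreadable. With all three values shown sitting at the limit, the expectation for compound 4 is that it will also reach that limit, so the step that the limit leaves unreadable from compound 1 to compound 4 is expected to be none beyond the scatter. Compound 4 is therefore estimated at 1 h, with a range from 0.5 h to 3 h, and most likely the assay will again report only a limit.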

Compound 4, half-life: > 0.5 h
Compound 4: no number, only a limit (the forecaster's own chance of this, stated with the estimate: 80%); the middle value is on the limit's open side.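

In this assay compound 4 gives > 0.5 h, again a limit and not a number. The steps to compound 4 from compound 1 and from compound 3 cannot be read: the limit of > 0.5 h in this assay, at which 4 of the 4 values shown sit.

The compounds shown leave open how long any of them actually lasts, and whether the group exchanged among compound 1, compound 3 and compound 4 changes the half-life at all.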